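Cyclohexyl for 3-(trifluoromethyl)benzyl: cytotoxicity outlook

The source may hold more compounds than are shown below. What is called first, only, known or untested is meant among the compounds shown, and "the series" means these compounds.

Going by the values given here, in a functional assay on SK-BR-3 cells (Homo sapiens) for cytotoxicity, read by MTT assay, with a stated time of 72 h (on this read-out higher numbers stand for weaker inhibition and lower numbers for stronger inhibition), compound 1 (`COc1ccc(CNC(=O)c2nc(Br)c3cccnc3c2N[C@H]2CC[C@H](N)CC2)cc1`) gives 5000 nM as the only number available so far. For compound 2 (`N[C@H]1CC[C@H](Nc2c(C(=O)NCc3cccc(C(F)(F)F)c3)nc(Br)c3cccnc23)CC1`) the entry in this assay reads "not determined" (no result reported) and so it holds no place on the scale. Compound 3 (`N[C@H]1CC[C@H](Nc2c(C(=O)NC3CCCCC3)nc(Br)c3cccnc23)CC1`) differs from compound 2 by cyclohexyl in place of 3-(trifluoromethyl)benzyl on an amide-type nitrogen with cyclohexyl in place of 3-(trifluoromethyl)benzyl on an amide-type nitrogen. Among the compounds with values here, no measured step shows what this change does. Within the data shown here, the only anchor is compound 1 at 5000 nM and no shift beyond the usual scatter from it is expected in this assay for now. Compound 3 is estimated at 5000 nM within an expected range from 1500 nM to 15000 nM pending measurement.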

Compound 3, half-maximal inhibitory concentration: 4200 nM
Compound 3: middle estimate off by 1.2-fold (0.08 log units), on the high side; the range from low to high includes it.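

This position now has its first measured step: cyclohexyl in place of 4-methoxybenzyl on the amide-type nitrogen gives a 1.2-fold lower number from compound 1 to compound 3 (0.08 log units; within the scatter) in this assay. Across these two compounds, an aromatic ring on this nitrogen is therefore not needed to keep the read-out at this level, since a non-aromatic carbon ring reads the same within the scatter. Nothing available bears on why the two groups read alike.

The compounds shown leave open how a straight hexyl chain, or a benzyl group carrying a carboxylic acid, would read on this nitrogen.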